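Working notes: adding hydroxy to compound 2

This account rests on a few compounds, and the source may have more. Where it says the series, first, only, none or still open, it means among the compounds named here.

- compound 1 `COc1cc2c(/C=C3/C(=O)Nc4ccc(Br)cc43)c(Cl)[nH]c2cc1C`: 2000 nM
- compound 2 `COc1cc2c(/C=C3/C(=O)N(C)c4ccccc43)c[nH]c2cc1C`: 7760 nM

In a functional assay on cells (Cancer cell lines, Homo sapiens) for inhibition, with a stated time of 48 h (on this read-out higher numbers stand for weaker inhibition of growth and lower numbers for stronger inhibition of growth), compound 2 (7760 nM) has the higher number of the two and so shows the weaker inhibition of growth. Compound 1 (2000 nM) has the lower number, and the gap between them lies beyond the scatter.

The next compound is compound 3 `COc1cc2c(/C=C3/C(=O)N(C)c4ccc(O)cc43)c[nH]c2cc1C`, which differs from compound 2 at a single place (hydroxy in place of hydrogen on an aromatic carbon): hydroxy in place of hydrogen on an aromatic carbon. Going by the values given here, no two measured compounds differ in only one place, so the series gives no direct measure of this change. Compound 1 (2000 nM) differs from compound 2 in more than one place and offers only a loose sign that lower numbers are reachable in this series.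

A small move toward stronger inhibition of growth is expected, not clearly beyond the scatter, and the estimate means a 1.7-fold lower number from compound 2 to compound 3 (0.24 log units; within the scatter) in this assay. The expected value for compound 3 is 4500 nM (estimated range 1500 nM to 15000 nM).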

Compound 3, concentration for 50% growth inhibition: 5620 nM
For compound 3 the middle estimate is 1.2-fold (0.10 log units) below the measured one, and the stated range covers the measured number.
By their numbers in this assay, from the lowest: compound 1; then compounds 3 and 2 (each within the scatter of the next).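

The series now has its first direct measure at this position: in this assay, hydroxy in place of hydrogen on an aromatic carbon gives a 1.4-fold lower number from compound 2 to compound 3 (0.14 log units; within the scatter). This step lies within the scatter, so on this background the carbon meta to a fused ring and para to a fused ring accepts a hydroxy, with its added hydrogen-bond donor and acceptor, without a difference that the read-out can separate from repeat measurement. No measured information bears on why this substitution gives this result.

As far as these compounds go, it remains open whether an amine or a carboxylic acid on this same aromatic carbon would also stay within the scatter of the hydrogen, or whether either would move the number clearly in one direction. From the compounds shown here alone, it is also open whether hydroxy would behave the same way on the core of compound 1, which differs from compound 2 and compound 3 in more than one place, so the features behind the value of compound 1 of 2000 nM cannot be separated.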